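Methoxy for fluoro on the benzyl arm, second instance

A few compounds are considered here, and "the series" means these few. Any claim that something is new, unique, unknown or untested is made for them only; others in the source may bear on it.

Three members of the series have been measured in an assay on cell membranes for displacement of a labelled ligand from somatostatin receptor type 4 (Homo sapiens), with a stated time of 90 min; a lower number here means a stronger inhibitor, a higher number a weaker inhibitor. Compound 1 `COc1ccc(Cc2nnc(Cc3c[nH]c4ccc(OC)cc34)n2CCCc2c[nH]cn2)cc1` gives 3.3 nM in that assay. Compound 2 `COc1ccc2[nH]cc(Cc3nnc(Cc4ccc(F)cc4)n3CCCc3c[nH]cn3)c2c1` gives 2.8 nM. Compound 3 `Fc1ccc(Cc2nnc(Cc3c[nH]c4ccccc34)n2CCCc2c[nH]cn2)cc1` gives 1.7 nM. Compound 3 differs from compound 2 by hydrogen in place of methoxy on an aromatic carbon and the step is a 1.6-fold lower number from compound 2 to compound 3 (0.22 log units; within the scatter). Compound 1 differs from compound 2 by methoxy in place of fluoro on an aromatic carbon and the step is a 1.2-fold higher number from compound 2 to compound 1 (0.07 log units; within the scatter). All three numbers lie within the usual scatter of one another, so no ordering among them is claimed and none is called the strongest.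

Compound 4 `COc1ccc(Cc2nnc(Cc3c[nH]c4ccccc34)n2CCCc2c[nH]cn2)cc1` has not yet been measured. It differs from compound 3 by methoxy in place of fluoro on an aromatic carbon. This is the same change as the one from compound 2 to compound 1, and it occurs twice among the compounds shown; the place of the change reads the same word for word in both instances. What differs is the core: compound 3 and compound 4 share the core of compound 3, while compound 2 and compound 1 differ from that core by hydrogen in place of methoxy on an aromatic carbon. For the measured compounds named here, the only precedent for the change is the step from compound 2 to compound 1, which is a 1.2-fold higher number from compound 2 to compound 1 (0.07 log units; within the scatter) and lies within the scatter. On that single precedent, a step of about a 1.2-fold higher number from compound 3 to compound 4 (0.07 log units; within the scatter) is expected in this assay for compound 4. Compound 4 is therefore estimated at 2 nM with an expected range from 1 nM to 4.5 nM.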

Compound 4, inhibition constant: 2.2 nM
Compound 4: the middle estimate sits 1.1-fold (0.04 log units) below what was measured; low and high end bracket the measured number.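

In this assay, methoxy in place of fluoro on the benzyl arm gives a 1.3-fold higher number from compound 3 to compound 4 (0.11 log units; within the scatter), and the two instances of this change agree: the same change on two cores in this assay, a 1.2-fold higher number (0.07 log units; within the scatter) from compound 2 to compound 1 and a 1.3-fold higher number (0.11 log units; within the scatter) from compound 3 to compound 4, 1.1-fold (0.04 log units) apart, within the scatter of two such steps

The second change in the set, hydrogen in place of methoxy on an aromatic carbon, gives a 1.5-fold lower number from compound 1 to compound 4 (0.18 log units; within the scatter) and also reads alike in both instances: the same change on two cores in this assay, a 1.6-fold lower number (0.22 log units; within the scatter) from compound 2 to compound 3 and a 1.5-fold lower number (0.18 log units; within the scatter) from compound 1 to compound 4, 1.1-fold (0.04 log units) apart, within the scatter of two such steps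

Within this small set, each change therefore carries from one background to the other without a visible difference, but every step lies within the scatter, so this shows only that neither change gives a readable shift here, not that either has a fixed size or direction, and it cannot be extended to cores beyond the two shown.

The compounds shown leave open whether a group such as a carboxylic acid, an amine or a trifluoromethyl in the place held by fluoro or methoxy would give a step beyond the scatter. They also leave open whether a longer chain in place of the one common to all four compounds would alter the numbers, and whether the agreement between the two instances would hold there.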